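A few compounds are considered here, and "the series" means these few. Any claim that something is new, unique, unknown or untested is made for them only; others in the source may bear on it.

Working notes on the series. Compound 1 `CC(C)OC(=O)N1CCC(O[C@H]2CC[C@H](Oc3ccc(S(C)(=O)=O)nc3)CC2)CC1` gives 125% in a functional assay on isolated protein for agonist activity at Glucose-dependent insulinotropic receptor (Rattus norvegicus), read by HTRF and cAMP accumulation; on this read-out higher numbers stand for larger maximal responses and lower numbers for smaller maximal responses. In this assay compound 2 `CC(C)(C)OC(=O)N1CCC(O[C@H]2CC[C@H](Oc3cnc(S(C)(=O)=O)cn3)CC2)CC1` gives 110%, and compound 3 `CC(C)OC(=O)N1CCC(O[C@H]2CC[C@H](Oc3cnc(S(C)(=O)=O)cn3)CC2)CC1` gives 120%. Compound 3 stands between the other two numbers, and each gap is within the scatter: a number 5 percentage points lower from compound 1 to compound 3 (within the scatter) and a number 10 percentage points higher from compound 2 to compound 3 (within the scatter). Compound 4 `CC1(OC(=O)N2CCC(O[C@H]3CC[C@H](Oc4cnc(S(C)(=O)=O)cn4)CC3)CC2)CC1` differs from compound 3 by 1-methylcyclopropyl in place of isopropyl on an oxygen next to a carbonyl group. The step bearing on this is the one at the same oxygen next to a carbonyl group, a number 10 percentage points higher from compound 2 to compound 3 (within the scatter), which stayed within the scatter; no other change at that place has been measured. The expected step in this assay is therefore no change at the digits printed from compound 3 to compound 4 (within the scatter), none beyond the scatter. Compound 4 is estimated at 120%, between 105% and 135%.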

Compound 4, largest response reached (Emax), in percent of the reference or control that the assay uses: 123%
Estimate against measurement, compound 4: 3 percentage points below, within the range that was stated.
By their numbers in this assay, from the lowest: compounds 2, 3, 4 and 1 (each within the scatter of the next, the first and the last beyond it).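

In this assay, among the compounds shown here, a ring enters on the oxygen next to a carbonyl group for the first time: 1-methylcyclopropyl in place of isopropyl gives a number 3 percentage points higher from compound 3 to compound 4 (within the scatter), so this ring is tolerated at this place. Against tert-butyl, the same group gives a number 13 percentage points higher from compound 2 to compound 4 (beyond the scatter), the first step at this place to pass the scatter, and a modest one. Nothing at hand gives a reason for either step. The compounds shown leave open how a cyclobutyl group or a chain ending in an amine would read at this oxygen. They also leave open whether 1-methylcyclopropyl reads the same with the 6-(methylsulfonyl)pyridin-3-yl group of compound 1.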